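From Dichlorophenoxy to Nitrophenoxy: What to Expect

A few compounds are considered here, and "the series" means these few. Any claim that something is new, unique, unknown or untested is made for them only; others in the source may bear on it.

Of the compounds shown here, three have been measured in an assay on HEK293 cells for displacement of a labelled ligand from Melanocortin receptor 4 (Homo sapiens); on this read-out higher numbers stand for weaker inhibition and lower numbers for stronger inhibition. Compound 1 `Cc1cc(Cl)ccc1CC(C)C(=O)N1CCN(c2ccc(C(F)(F)F)cc2[C@@H](N)CC(C)C)CC1` gives 38 nM, and compound 3 `COc1ccc(CC(C)C(=O)N2CCN(c3ccc(C(F)(F)F)cc3[C@@H](N)CC(C)C)CC2)cc1` gives 120 nM. Compound 2 `CC(C)C[C@H](N)c1cc(C(F)(F)F)ccc1N1CCN(C(=O)COc2cccc(Cl)c2Cl)CC1` gives 2500 nM, the highest number of the three, set apart beyond the scatter by the steps of a 66-fold higher number from compound 1 to compound 2 (1.82 log units; beyond the scatter) and a 21-fold lower number from compound 2 to compound 3 (1.32 log units; beyond the scatter). Compound 4 `CC(C)C[C@H](N)c1cc(C(F)(F)F)ccc1N1CCN(C(=O)COc2ccc([N+](=O)[O-])cc2)CC1` is built from compound 2 by a single change: 4-nitrophenyl in place of 2,3-dichlorophenyl on an oxygen on a saturated carbon. Going by the values given here, no measured step alters this ring while keeping the rest of the molecule: the two large steps exchange the whole group on the carbonyl carbon, and the modest step of a 3.2-fold higher number from compound 1 to compound 3 (0.50 log units; beyond the scatter) swaps substituents on a ring that sits on a saturated chain carbon rather than on an oxygen. That last step suggests that changing the substituents on an outer ring shifts this assay only a little. A similar outcome is expected for compound 4, whose step a 1.4-fold higher number from compound 2 to compound 4 (0.15 log units; within the scatter) is estimated to remain near the scatter. Compound 4 is therefore expected to give about 3500 nM, within a range of 1000 nM to 12000 nM.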

Compound 4, inhibition constant: 3100 nM
Estimate against measurement, compound 4: 1.1-fold (0.05 log units) above; measured number inside the range.
By their numbers in this assay, from the lowest: compound 1; then compound 3; then compounds 2 and 4 (each within the scatter of the next).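

In this assay, going by these compounds alone, this is the first direct change to the ring on the oxygen: 4-nitrophenyl in place of 2,3-dichlorophenyl gives a 1.2-fold higher number from compound 2 to compound 4 (0.09 log units; within the scatter) and so leaves the two compounds indistinguishable, although two chlorine atoms have given way to a nitro group. The large shifts stay with the whole group on the carbonyl carbon, where (4-nitrophenoxy)methyl in place of 1-(4-methoxybenzyl)ethyl gives a 26-fold higher number from compound 3 to compound 4 (1.41 log units; beyond the scatter) and in place of 1-(4-chloro-2-methylbenzyl)ethyl gives an 82-fold higher number from compound 1 to compound 4 (1.91 log units; beyond the scatter) in this set of compounds. No measurement at hand explains why these two rings read alike.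

Going by these compounds, two substitution patterns are a narrow sample, so it remains open whether an amine or a carboxylic acid on this ring would also leave the number in place. A longer chain between the oxygen and the ring is likewise untested among these compounds.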